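A few compounds are considered here, and "the series" means these few. Any claim that something is new, unique, unknown or untested is made for them only; others in the source may bear on it.

Working notes on the series. Among the measured compounds shown here, compound 2 `CCC(C)(C)Cc1c[nH]c(CCc2ccc(-c3ccccc3C(=O)O)cc2)n1` stands at the higher of the two numbers measured so far in a functional assay on HEK293 cells for agonist activity at Bombesin receptor subtype-3 (Homo sapiens), read by luminescence and calcium flux, with a stated time of 10 min (a lower number here means that less compound is needed, a higher number that more compound is needed for the effect), where compound 2 gives 101 nM. For the measured compounds named here, its only neighbour is compound 1 `CCC(C)(C)Cc1c[nH]c(CCc2ccc(-n3ccnn3)cc2)n1`, and in this assay compound 1 gives 93 nM. The step of a 1.1-fold higher number from compound 1 to compound 2 (0.04 log units; within the scatter) puts the two compounds within the scatter of each other, so no order between them is claimed.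

Compound 3 `CCC(C)(C)Cc1c[nH]c(CCc2ccc(-n3cncn3)cc2)n1` has not yet been measured. It differs from compound 2 by 1H-1,2,4-triazol-1-yl in place of 2-carboxyphenyl on an aromatic carbon, the new group sitting on an aromatic carbon of a six-membered aromatic ring of carbon only, para to a large group. Going by the values given here, the only measured step that bears on this change is the one between compound 1 and compound 2, which swapped a five-membered aromatic ring with three hetero atoms for the 2-carboxyphenyl and moved the number by a 1.1-fold higher number from compound 1 to compound 2 (0.04 log units; within the scatter), within the scatter. Reversing that exchange with a closely related five-membered ring is therefore expected to give a step of a 1.1-fold lower number from compound 2 to compound 3 (0.05 log units; within the scatter), with no change beyond the scatter. Compound 3 is expected at 90 nM, in the range 40 nM to 200 nM.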

Compound 3, half-maximal effective concentration: 89 nM
Beside the measured number, compound 3's estimate is 1.0-fold (0.00 log units) above it; measured number inside the range.
By their numbers in this assay, from the lowest: compounds 3, 1 and 2 (each within the scatter of the next).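

At this place, on an aromatic carbon of a six-membered aromatic ring of carbon only, para to a large group, 1H-1,2,4-triazol-1-yl in place of 2-carboxyphenyl gives a 1.1-fold lower number from compound 2 to compound 3 (0.05 log units; within the scatter) in this assay, and 1H-1,2,4-triazol-1-yl in place of 1H-1,2,3-triazol-1-yl gives a 1.0-fold lower number from compound 1 to compound 3 (0.02 log units; within the scatter). The second step adds what the earlier pair could not show: two different five-membered aromatic rings with 3 hetero atoms are not told apart here, and among these three compounds neither the change from 9 to 5 heavy atoms nor the loss of the hydrogen-bond donor of the 2-carboxyphenyl moves the number beyond the scatter. No measurement at hand offers a reason for this flat picture.

The compounds shown leave open whether the number at this place would respond to a group of another kind, such as an amine or a saturated ring like morpholine, or to a carboxylic acid set directly on the ring without the intervening phenyl. They also leave open whether the same flat picture would hold with a longer chain on the shared core.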